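A carbamate in place of an amide at the lipophilicity ceiling

The source may report more compounds than this note shows. Statements on the series, on what has been measured and on what is new or still open speak of the compounds shown alone.

Compound 1 `Cc1cc(C(=O)NCc2ccccc2)nn1Cc1cc(Cl)ccc1OCc1ccccc1` is recorded in a physicochemical assay for lipophilicity, at pH 7.4 (a higher number here means a more lipophilic compound, a lower number a more polar compound), only as a limit, > 3.7. Compound 3 `Cc1cc(NC(=O)C2CCOC2)nn1Cc1cc(Cl)ccc1OCc1ccccc1` likewise reaches a limit, > 3.7. Compound 2 `Cc1cc(C(=O)NN2CCOCC2)nn1Cc1cc(Cl)ccc1OCC(C)C` gives 3.1 in this assay. Going by the values given here, the one single-point step, a step that the two limits leave unreadable from compound 1 to compound 3, stays unreadable because the limit of > 3.7 in this assay, at which 2 of the 3 values shown sit, hides both of its ends. Compound 4 `Cc1cc(NC(=O)OCc2ccccc2)nn1Cc1cc(Cl)ccc1OCc1ccccc1` differs from compound 1 as follows: (benzyloxycarbonyl)amino in place of benzylcarbamoyl on an aromatic carbon. Among the compounds with values here, no measured step bears directly on this change, and the limit on compound 1 gives no number to start from. Compound 4 is expected to remain at or beyond that limit, so the step that the limit leaves unreadable from compound 1 to compound 4 is expected to be small. Compound 4 is estimated at 4.2 in this assay, between 3.6 and 4.9.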

Compound 4, distribution coefficient: 3.1
Compound 4: the middle estimate sits 1.10 log units above what was measured, and the stated range ends above it.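

At this position, (benzyloxycarbonyl)amino in place of benzylcarbamoyl gives a number at least 0.60 log units lower from compound 1 to compound 4 (beyond the scatter) in this assay, a direction the unreadable step to compound 3 could not supply. On the carbonyl carbon, benzyloxy in place of oxolan-3-yl gives a number at least 0.60 log units lower from compound 3 to compound 4 (beyond the scatter), so the group on that carbonyl also shifts the number. Each step has only one readable end, and its full size stays unknown: the limit of > 3.7 in this assay, at which 2 of the 4 values shown sit.

Going by these compounds, it remains open whether a longer chain in place of benzyloxy on that carbonyl would keep the number this low, and what an amine there would give.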